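The compounds below may be only part of what the source reports. "The series", "measured", "known", "first", "only" and "open" are said of these compounds alone.

Compound 1 `COC(=O)c1ccc2ccc(C(=O)N(C)C)c-2cc1` is the starting point of this account. In a physicochemical assay for solubility, with a stated time of 24 h, at pH 6.8 (a higher number here means a more soluble compound, a lower number a less soluble compound), compound 1 gives > 64 ug/mL as its reading, and that reading is a limit of the assay, not a number. Compound 2 `COC(=O)c1ccc2c(C(=O)Nc3ccccc3)cn(C)c2c1` gives < 1 ug/mL as its reading, and this too is a limit. Going by the values given here, compound 1 therefore stands at the high end of the two known values, and no measured step connects it to compound 2, whose core is different.

Among the compounds with values here, compound 3 `COC(=O)c1ccc2ccc(C(=O)Nc3ccccc3)c-2cc1` keeps the core of compound 1 and changes only one group: anilino in place of dimethylamino on a carbonyl carbon with anilino in place of dimethylamino on a carbonyl carbon. Within the data shown here, compound 2, the only measured compound that carries anilino there, shows the limit < 1 ug/mL in this assay on its own core. On that ground, a downward step beyond the usual scatter is expected in this assay for compound 3, although the difference in core leaves its size uncertain. The estimated change is an at least 16-fold lower number from compound 1 to compound 3 (1.20 log units; beyond the scatter) in this assay. For compound 3 the expected reading is 4 ug/mL with an estimated range from 0.7 ug/mL to 25 ug/mL overall.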

Compound 3, solubility: < 1 ug/mL
Compound 3 was reported as a limit; the forecaster's own chance of this, stated with the estimate: 30%; at least 4.0-fold (0.60 log units) between middle value and limit.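

On the core of compound 1, anilino in place of dimethylamino on a carbonyl carbon gives an at least 64-fold lower number from compound 1 to compound 3 (1.80 log units; beyond the scatter) in this assay. Going by these compounds alone, this is the first step in the account that isolates this position, as compound 2 differs from compound 1 in more than one place and could not show what this one change does. With the core held fixed, the swap alone is enough to take the reading from one end of the range shown to the other, so the low end is not confined to the core of compound 2: the limit of < 1 ug/mL in this assay, at which 2 of the 3 values shown sit.

On these data alone, the true size of the step remains open, as the readings of compound 1 and compound 3 are both limits of the assay and the step fixes only a minimum: the limit of > 64 ug/mL in this assay, at which 1 of the 3 values shown sits. Also open is how a reading in this assay would respond to intermediate groups on this carbonyl carbon, such as methylamino or morpholine, or to an anilino ring carrying a carboxylic acid or an amine, and whether any of these would fall inside the range left unresolved by these two limits.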